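Bromo to methyl on the aryl ring of a thiazolylidene hydrazide

The compounds below may be only part of what the source reports. "The series", "measured", "known", "first", "only" and "open" are said of these compounds alone.

Compounds measured so far:
compound 1 `Cc1ccc(-c2cs/c(=N/NC(=O)CSc3nncn3C)n2-c2ccccc2)cc1`, 70.7%
compound 2 `Cc1ccc(-c2cs/c(=N/NC(=O)CSc3nnnn3C)n2-c2ccccc2)cc1`, 60.7%
compound 3 `O=C(CSc1ncccn1)N/N=c1/scc(-c2ccc(Br)cc2)n1-c1ccccc1`, 72.3%

All three were tested in a functional assay on C6 cells (Rattus norvegicus) for cytotoxicity, read by MTT assay, with a stated time of 24 h, tested at 25 ug/mL; a higher number here means a weaker effect of the compound at the concentration tested, a lower number a stronger effect. Compound 3 gives the highest of the three numbers, 72.3%, while compound 1 gives 70.7%, a gap within the scatter, and compound 2 gives 60.7%, a gap beyond the scatter. For the measured compounds named here, the one step measured between neighbours, a number 10 percentage points lower from compound 1 to compound 2 (within the scatter), concerns the heteroaryl group on the sulfur and not the aryl ring, so it does not bear on the change considered here.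

Compound 4 `Cc1ccc(-c2cs/c(=N/NC(=O)CSc3ncccn3)n2-c2ccccc2)cc1` has not yet been measured in this assay. It differs from compound 3 by methyl in place of bromo on an aromatic carbon. Going by the values given here, no measured pair shows this exchange, so nothing in the data suggests a step in either direction. Compound 1 carries the same methylphenyl group as compound 4, and its value sits close to that of compound 3, which supports the expectation of no step beyond the scatter.

The step from compound 3 to compound 4 is therefore expected to be a number 1.3 percentage points lower from compound 3 to compound 4 (within the scatter). Compound 4 is expected to give about 71%, between 60% and 82%.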

Compound 4, a percentage reported as activity, at one concentration (the size of the read-out at that concentration, not a potency): 82.7%
Compound 4: middle estimate off by 11.7 percentage points, on the low side; measured number outside the range, above it.
By their numbers in this assay, from the lowest: compounds 2, 1 and 3 (each within the scatter of the next, the first and the last beyond it); then compound 4.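

In this assay, for the compounds shown here, the exchange on this aromatic carbon, para to a large group, turns out not to be silent: 4-bromophenyl to 4-methylphenyl gives a number 10.4 percentage points higher from compound 3 to compound 4 (beyond the scatter) in the one pair available, so bromo goes with the stronger effect at the concentration tested when pyrimidin-2-yl sits on the sulfur. With the 4-methylphenyl group held constant, the group on the sulfur also emerges as a second place of change, since pyrimidin-2-yl in place of 1-methyl-1H-tetrazol-5-yl gives a number 22 percentage points higher from compound 2 to compound 4 (beyond the scatter) and pyrimidin-2-yl in place of 4-methyl-4H-1,2,4-triazol-3-yl gives a number 12 percentage points higher from compound 1 to compound 4 (beyond the scatter) in the same read-out. Nothing at hand explains either change.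

On these data alone, whether bromo in place of methyl would bring a similar step with 4-methyl-4H-1,2,4-triazol-3-yl or 1-methyl-1H-tetrazol-5-yl on the sulfur stays open, as the exchange is seen with pyrimidin-2-yl alone. The compounds shown also leave open how chloro, methoxy, an amine or a carboxylic acid would read on this aromatic carbon, and whether the trend from bromo to methyl would extend to a longer chain there.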